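Anilide halogen pattern in the thioacetamide series

The source may hold more compounds than are shown below. What is called first, only, known or untested is meant among the compounds shown, and "the series" means these compounds.

Three compounds share one core and differ only in the anilide ring. Compound 1 `O=C(CSc1nc(Nc2ccccc2)c2ccccc2n1)Nc1cccc(F)c1` gives 6790 nM in a functional assay on NCI-H1975 cells (Homo sapiens) for inhibition, read by MTT assay, with a stated time of 72 h; on this read-out lower numbers stand for stronger inhibition and higher numbers for weaker inhibition. Compound 2 `O=C(CSc1nc(Nc2ccccc2)c2ccccc2n1)Nc1cccc(Cl)c1` gives 8460 nM, and compound 3 `O=C(CSc1nc(Nc2ccccc2)c2ccccc2n1)Nc1ccc(F)cc1` gives 16500 nM. Among the measured compounds shown here, compound 3 thus carries the highest of the three numbers, though only the step of a 2.4-fold higher number from compound 1 to compound 3 (0.39 log units; beyond the scatter) lies beyond the scatter, while a 2.0-fold higher number from compound 2 to compound 3 (0.29 log units; within the scatter) stays within it. The swap of halogen alone, a 1.2-fold higher number from compound 1 to compound 2 (0.10 log units; within the scatter), changes little.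

Compound 4 `O=C(CSc1nc(Nc2ccccc2)c2ccccc2n1)Nc1ccc(Cl)cc1Cl` is the next step: 2,4-dichlorophenyl in place of 4-fluorophenyl on an amide-type nitrogen. For the measured compounds named here, two measured steps bear on it. The halogen swap from compound 1 to compound 2 suggests that chloro for fluoro at the same place moves the number little. Going by these compounds, the second chloro enters at a place not covered by any measured compound, so its effect is unknown. From compound 3 to compound 4 a small step is therefore expected, a 1.5-fold lower number from compound 3 to compound 4 (0.18 log units; within the scatter), likely toward a lower number but not clearly beyond the scatter. Compound 4 is estimated at 11000 nM, within a range from 4500 nM to 28000 nM.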

Compound 4, half-maximal inhibitory concentration: 8410 nM
Beside the measured number, compound 4's estimate is 1.3-fold (0.12 log units) above it, within the range that was stated.
By their numbers in this assay, from the lowest: compounds 1, 4, 2 and 3 (each within the scatter of the next, the first and the last beyond it).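

With 2,4-dichlorophenyl on the amide-type nitrogen, the series gives a 2.0-fold lower number from compound 3 to compound 4 (0.29 log units; within the scatter), and the same group gives a 1.0-fold lower number from compound 2 to compound 4 (0.00 log units; within the scatter) and a 1.2-fold higher number from compound 1 to compound 4 (0.09 log units; within the scatter). Compound 4 therefore cannot be told apart from any of the three earlier compounds in this assay, which shows that a ring with two chloro groups at this place stays within the scatter of each ring with a single halogen. No measurement is at hand that could explain this result.

Still open, going by these compounds, is how this place responds to a group other than a halogen, such as methoxy, an amine or a carboxylic acid on the anilide ring. Also open, on these data alone, is what a longer chain in place of the thioacetamide link would do to the number.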